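Cyclohexyl sulfamide to phenylamide: expected gain

This account rests on a few compounds, and the source may have more. Where it says the series, first, only, none or still open, it means among the compounds named here.

Measured so far:
- compound 1 `O=C(/C(=N/O)Nc1ccc(F)c(Br)c1)C1CCN(S(=O)(=O)NCc2ccccc2)CC1`: 24 nM
- compound 2 `NS(=O)(=O)NC[C@H]1CC[C@H](C(=O)/C(=N/O)Nc2ccc(F)c(Br)c2)CC1`: 198 nM
- compound 3 `O=C(/C(=N/O)Nc1ccc(F)c(Br)c1)C1CCN(C(=O)NCc2ccccc2)CC1`: 43 nM

All three share the same oxime-amide core and were run in an assay for inhibition of Indoleamine 2,3-dioxygenase 1 (Homo sapiens), with a stated time of 1 h; a lower number here means a stronger inhibitor, a higher number a weaker inhibitor. Compound 2 stands highest of the three numbers; compound 3 is nearest, compound 1 furthest, both beyond the scatter. Compounds 1 and 3 carry an aryl-bearing group on the saturated ring and their values lie within the scatter of each other.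

Compound 4 `O=C(Nc1ccccc1)[C@H]1CC[C@H](C(=O)/C(=N/O)Nc2ccc(F)c(Br)c2)CC1` is not yet measured. Its change from compound 2: phenylcarbamoyl in place of (sulfamoylamino)methyl on a saturated ring carbon. This brings an aromatic ring back into the side group, as compounds 1 and 3 have. The step is expected to be a 4.0-fold lower number from compound 2 to compound 4 (0.60 log units; beyond the scatter) because compound 3 gives 43 nM. Compound 4 is estimated at 50 nM, range 15 nM to 160 nM.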

Compound 4, half-maximal inhibitory concentration: 150 nM
Estimate against measurement, compound 4: 3.0-fold (0.48 log units) below, within the range that was stated.
By their numbers in this assay, from the lowest: compounds 1 and 3 (each within the scatter of the next); then compounds 4 and 2 (each within the scatter of the next).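

In this assay phenylcarbamoyl in place of (sulfamoylamino)methyl on a saturated ring carbon gives a 1.3-fold lower number from compound 2 to compound 4 (0.12 log units; within the scatter) and so leaves the number unresolved from that of compound 2. At this position, an aromatic ring entering the side group is thus not enough on its own to produce a step beyond the scatter. Nothing available explains this result.

Open, going by these compounds, is whether an amine, a carboxylic acid or a longer chain ending in phenyl on this ring carbon would give a different number. On these data alone, compounds 1 and 3 differ from compound 4 in more than one place, so the part played by the ring itself also stays open.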